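Phenylsulfonyl to phenylsulfanyl: notes on compound 3

The compounds below may be only part of what the source reports. "The series", "measured", "known", "first", "only" and "open" are said of these compounds alone.

Measured so far:
- compound 1 `CCN(CC)CCNC(=O)c1ccc(C(CC)(CC)c2ccc(OCS(=O)(=O)c3ccccc3)c(C)c2)n1CC`: 7130 nM
- compound 2 `CCn1c(C(=O)N[C@H](CO)C(C)C)ccc1C(CC)(CC)c1ccc(OCS(=O)(=O)c2ccccc2)c(C)c1`: 7300 nM

Among the compounds with values here, in a functional assay on PC-3 cells (Homo sapiens) for antiproliferative activity, read by MTT assay, with a stated time of 24 h (on this read-out lower numbers stand for stronger inhibition and higher numbers for weaker inhibition), compound 1 stands level with compound 2, the only other measured compound, and the two cannot be ranked. Compound 3 `CCN(CC)CCNC(=O)c1ccc(C(CC)(CC)c2ccc(OCSc3ccccc3)c(C)c2)n1CC` is still unmeasured. It differs from compound 1 as follows: phenylsulfanyl in place of phenylsulfonyl on a saturated chain carbon bound to an oxygen on an aromatic ring. In words, phenylsulfanyl replaces phenylsulfonyl on a saturated chain carbon bound to an oxygen on an aromatic ring. Within the data shown here, the one measured step, a 1.0-fold higher number from compound 1 to compound 2 (0.01 log units; within the scatter), concerns the group on an amide-type nitrogen, so no measurement tests this change directly. With no direction supported by the data, no shift beyond the scatter is expected in this assay, although the uncertainty is wide. The expected step is a 1.0-fold lower number from compound 1 to compound 3 (0.01 log units; within the scatter). For compound 3 the estimated value is 7000 nM, with an expected range from 2500 nM to 20000 nM.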

Compound 3, half-maximal inhibitory concentration: 2230 nM
Beside the measured number, compound 3's estimate is 3.1-fold (0.50 log units) above it, and the stated range ends above it.
By their numbers in this assay, from the lowest: compound 3; then compounds 1 and 2 (each within the scatter of the next).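

In this assay, the position on a saturated chain carbon bound to an oxygen on an aromatic ring responds to the group it carries: phenylsulfanyl in place of phenylsulfonyl gives a 3.2-fold lower number from compound 1 to compound 3 (0.50 log units; beyond the scatter), a modest step. Within the data shown here, the earlier change on the amide-type nitrogen, a 1.0-fold higher number from compound 1 to compound 2 (0.01 log units; within the scatter), gave no such separation, so this is the first change to move the number beyond the scatter. Nothing available bears on why the number falls with this exchange.

Open, on these data alone, is how the read-out responds to other groups at this position, such as phenylsulfinyl, with its single oxygen on the sulfur, or phenoxy, with oxygen in place of the sulfur. Also open, as far as these compounds go, is whether the same exchange gives a similar step alongside 1-(hydroxymethyl)-2-methylpropyl on the amide-type nitrogen.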